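The source may report more compounds than this note shows. Statements on the series, on what has been measured and on what is new or still open speak of the compounds shown alone.

In a functional assay on P388 cells (Mus musculus) for antiproliferative activity (on this read-out lower numbers stand for stronger inhibition and higher numbers for weaker inhibition), compound 2 `N#Cc1ccc(S(=O)(=O)Nc2cccc3c(C#N)c[nH]c23)cc1` gives 0.53 ug/mL, the lowest of the three numbers measured, ahead of compound 1 `N#Cc1ccc(S(=O)(=O)Nc2cccc3cc[nH]c23)cc1` at 4.2 ug/mL and compound 3 `N#Cc1ccccc1S(=O)(=O)Nc1cccc2c(C#N)c[nH]c12` at 14 ug/mL. Compound 4 `CS(=O)(=O)Nc1ccc(S(=O)(=O)Nc2cccc3c(C#N)c[nH]c23)cc1` carries methanesulfonamido in place of cyano on an aromatic carbon, para to a large group: methanesulfonamido in place of cyano on an aromatic carbon. Among the measured compounds shown here, no measured step makes this swap. For the measured compounds named here, the one single change measured, a 7.9-fold lower number from compound 1 to compound 2 (0.90 log units; beyond the scatter), lies at a different place and only shows that a modest step is possible on this series. Compound 3, with its value of 14 ug/mL, shows that numbers can climb well above that of compound 2 when the nitrile-bearing ring is altered. A modest rise is therefore expected, a 1.9-fold higher number from compound 2 to compound 4 (0.28 log units; within the scatter), though it may stay within the scatter. For compound 4 the estimated value is 1 ug/mL, with an expected range from 0.2 ug/mL to 5 ug/mL.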

Compound 4, half-maximal inhibitory concentration: 3.5 ug/mL
The estimate for compound 4 lay 3.5-fold (0.54 log units) below the measured number; the range from low to high includes it.
By their numbers in this assay, from the lowest: compound 2; then compounds 4 and 1 (each within the scatter of the next); then compound 3.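

In this assay, among the compounds shown here, methanesulfonamido in place of cyano brings a 6.6-fold higher number from compound 2 to compound 4 (0.82 log units; beyond the scatter) and gives the first reading of a single change at this place, on an aromatic carbon para to a large group. The result shows that the number responds to what sits there and that these two groups are not interchangeable. Nothing available accounts for the size or direction of this step. For the compounds shown here, with only two groups compared here, one step cannot define a trend. Going by these compounds, how an amine, a carboxylic acid or a fluorine at this place would compare with cyano remains open.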